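This account rests on a few compounds, and the source may have more. Where it says the series, first, only, none or still open, it means among the compounds named here.

Working notes on the series. Two compounds have a number in a functional assay on cells (T-cell, Homo sapiens) for inhibition; on this read-out lower numbers stand for stronger inhibition and higher numbers for weaker inhibition. Compound 1, `COc1ccc(-c2cnc3nc(N)nc(NC(C)C)c3n2)cc1OC`, gives 600 nM in this assay. Compound 2, `CCOc1nc(N)nc2ncc(-c3ccc(CC)cc3)nc12`, gives 8200 nM in this assay, and so stands at the highest of the two numbers; the gap between compound 1 and compound 2 lies beyond the scatter of repeated measurements, but no single-point change links the two structures, so the two values are noted side by side and nothing more is read from them.

The next compound, compound 3, `CCOc1nc(N)nc2ncc(-c3ccc(C(F)(F)F)cc3)nc12`, is unmeasured. Its difference from compound 2 is as follows: trifluoromethyl in place of ethyl on an aromatic carbon. The group sits on the phenyl ring, para to a large group; both groups carry no donors or acceptors and no charge.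

Going by the values given here, no measured pair in this set shows what such an exchange does to the read-out, so the expectation rests on compound 2 alone. For compound 3 the estimate in this assay is 10000 nM, with a range of 3000 nM to 30000 nM. The step that this estimate means, a 1.2-fold higher number from compound 2 to compound 3 (0.09 log units; within the scatter), is expected to stay within the scatter, with no direction claimed.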

Compound 3, half-maximal inhibitory concentration: 10000 nM
For compound 3 middle estimate and measured number coincide at the digits printed; low and high end bracket the measured number.
By their numbers in this assay, from the lowest: compound 1; then compounds 2 and 3 (each within the scatter of the next).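

Trifluoromethyl in place of ethyl on an aromatic carbon, para to a large group, gives in this assay a 1.2-fold higher number from compound 2 to compound 3 (0.09 log units; within the scatter), and this is the first single-point step that can be read in the series. At this place on the phenyl ring, the read-out does not separate the two groups, although ethyl brings 2 heavy atoms and trifluoromethyl brings 4, and neither carries a hydrogen-bond donor, a hydrogen-bond acceptor or a net charge. No measurement shown gives a reason for this outcome.

Going by these compounds alone, the step covers only this one exchange, so it remains open whether an amine, a carboxylic acid or a longer chain such as butyl at the same place would give a number beyond the scatter from compound 2. As far as these compounds go, compound 1 differs from both compound 2 and compound 3 in more than one place, so its lower number cannot be assigned to any single part of its structure, and the effect of the phenyl substituents on the core of compound 1 also remains open.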